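A few compounds are considered here, and "the series" means these few. Any claim that something is new, unique, unknown or untested is made for them only; others in the source may bear on it.

Working notes on the series. In a functional assay on MCF7 cells (Homo sapiens) for cytotoxicity, read by MTT assay, with a stated time of 96 h (a lower number here means a stronger inhibitor, a higher number a weaker inhibitor), compound 1 (`COc1cc(C(=O)c2cn(-c3ccc(C)cc3)cc2-c2ccc([N+](=O)[O-])cc2)cc(OC)c1OC`) gives 200 nM and compound 2 (`COc1cc(C(=O)c2cn(-c3ccc(N)cc3)cc2-c2ccccc2[N+](=O)[O-])cc(OC)c1OC`) gives 53 nM on the same read-out. Compound 2 therefore holds the lower of the two numbers, and its gap to compound 1 lies beyond the scatter. Next comes compound 3 (`COc1cc(C(=O)c2cn(-c3ccc(N)cc3)cc2-c2ccc([N+](=O)[O-])cc2)cc(OC)c1OC`), which has 4-nitrophenyl in place of 2-nitrophenyl on an aromatic carbon. Among the compounds with values here, no measured pair isolates this change, so its size remains open. Within the data shown here, compound 1 also carries 4-nitrophenyl and gives 200 nM as the only reading with that group, which points towards a higher number, though only weakly. The expected change is a small rise (a 1.5-fold higher number from compound 2 to compound 3 (0.18 log units; within the scatter)) that stays within the scatter. Compound 3 is estimated at 80 nM with an expected range from 20 nM to 300 nM in this assay when measured.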

Compound 3, half-maximal inhibitory concentration: 260 nM
Estimate against measurement, compound 3: 3.3-fold (0.51 log units) below; the range from low to high includes it.
By their numbers in this assay, from the lowest: compound 2; then compounds 1 and 3 (each within the scatter of the next).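

With 4-aminophenyl held constant, 4-nitrophenyl in place of 2-nitrophenyl on this aromatic carbon of the five-membered ring gives a 4.9-fold higher number from compound 2 to compound 3 (0.69 log units; beyond the scatter) in this assay, so this pair shows that the two nitrophenyl isomers are not interchangeable at this position. With 4-nitrophenyl held constant, amino in place of methyl on the other aryl group gives a 1.3-fold higher number from compound 1 to compound 3 (0.11 log units; within the scatter), so that change does not separate from the scatter in this pair. No measured information on the compounds accounts for either step.

On these data alone, whether amino and methyl would also read alike alongside 2-nitrophenyl remains open. As far as these compounds go, it is also open how a plain phenyl, or a carboxylic acid in place of the nitro group, would read at this position.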